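This account rests on a few compounds, and the source may have more. Where it says the series, first, only, none or still open, it means among the compounds named here.

Measured compounds:

compound 1 `COc1ccccc1C(=O)/C=C/CCc1ccccc1` gives 1720 nM
compound 2 `COc1ccc(C(=O)/C=C/CCc2ccccc2)cc1` gives 3870 nM
compound 3 `O=C(/C=C/CCc1ccccc1)c1ccccc1-c1ccccc1` gives 1230 nM

All three were tested in a functional assay on HEK293 cells for antagonist activity at G-protein coupled receptor 52 (Homo sapiens), read by cAMP accumulation, with stated times of 15 min and 30 min; on this read-out lower numbers stand for stronger inhibition and higher numbers for weaker inhibition. Compound 2 has the highest of the three numbers; it differs from compound 1 in that the two have the same atoms joined differently, and the difference between the two cores is not broken down here. Compound 3 arises from compound 1 by one change, (phenyl in place of methoxy on an aromatic carbon), and this change made a step of a 1.4-fold lower number from compound 1 to compound 3 (0.15 log units; within the scatter).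

Compound 4 `O=C(/C=C/CCc1ccccc1)c1ccc(-c2ccccc2)cc1` has not yet been measured in this assay. It arises from compound 2 by phenyl in place of methoxy on an aromatic carbon. Among the measured compounds shown here, this is the same kind of change as the one from compound 1 to compound 3, but the two places are not the same: in compound 3 the entering group sits ortho to a large group, in compound 4 it sits para to a large group. Whether that difference in place matters cannot be read from the three measured compounds, since the change occurs only once among them.

For compound 4 the expected step in this assay is a 1.5-fold lower number from compound 2 to compound 4 (0.17 log units; within the scatter), resting on the earlier step of a 1.4-fold lower number from compound 1 to compound 3 (0.15 log units; within the scatter) in the same direction. The estimate for compound 4 is 2600 nM, with a range from 900 nM to 7500 nM to allow for the different place of the change.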

Compound 4, half-maximal inhibitory concentration: 7640 nM
Compound 4: middle estimate off by 2.9-fold (0.47 log units), on the low side; the measured number lies above the stated range.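

In this assay, putting phenyl in place of methoxy on an aromatic carbon of the core of compound 2 gives a 2.0-fold higher number from compound 2 to compound 4 (0.30 log units; within the scatter), so this step alone cannot be told apart from repeat-to-repeat variation. Each of the two steps lies within the scatter, yet set side by side they point in opposite directions and the gap between them does not: the same change on two cores in this assay, a 1.4-fold lower number (0.15 log units; within the scatter) from compound 1 to compound 3 and a 2.0-fold higher number (0.30 log units; within the scatter) from compound 2 to compound 4, 2.8-fold (0.44 log units) apart, beyond the scatter of two such steps This shows that the effect of this change on one core was not a reliable guide to its effect on the other, but it rests on a single pair of steps and does not show whether the difference comes from the cores themselves or from where the phenyl sits, since in compound 4 it is para to a large group and in compound 3 it sits at a different place.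

A third core carrying the same methoxy-to-phenyl change would help separate these two explanations, and the compounds shown leave that open. They also leave open how an amine, a carboxylic acid or a longer chain would read in place of the phenyl on either core.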